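Methoxy in Place of Methyl on the Shared Core

This account rests on a few compounds, and the source may have more. Where it says the series, first, only, none or still open, it means among the compounds named here.

Three compounds carry a value in a functional assay on HT-29 cells (Homo sapiens) for antiproliferative activity, read by sulforhodamine B assay, with a stated time of 72 h; a lower number here means a stronger inhibitor, a higher number a weaker inhibitor. Compound 1 `FC(F)(F)c1ccccc1NC(=S)N/N=C/c1ccc2ccccc2n1` gives 18100 nM in this assay and is the only one of the three to yield a number. Compound 2 `Cc1cccc(NC(=S)N/N=C/c2ccc3ccccc3n2)c1` is reported in this assay only as a limit of the assay, > 100000 nM. Compound 3 `NC(=S)N/N=C/c1nc2ccccc2s1` is likewise reported in this assay only as a limit, > 100000 nM. Within the data shown here, compound 2 therefore stands at the limit of > 100000 nM in this assay, at which 2 of the 3 values shown sit, and no measured pair differs in a single place, so no measured step is available.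

Compound 4 `COc1cccc(NC(=S)N/N=C/c2ccc3ccccc3n2)c1` differs from compound 2 by methoxy in place of methyl on an aromatic carbon. Among the measured compounds shown here, nothing among the measured compounds shows what this exchange does in this assay, and the starting point, compound 2, is itself only a limit. For the measured compounds named here, the only anchor is compound 2, whose value is the limit > 100000 nM. The expected step is a number no higher from compound 2 to compound 4 (the limit leaves the size open), that is, none beyond the scatter. Compound 4 is accordingly estimated at 100000 nM in this assay, within a range from 40000 nM to 300000 nM, with a substantial chance that the assay again reports only a limit rather than a number.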

Compound 4, half-maximal inhibitory concentration: 82400 nM
The estimate for compound 4 lay 1.2-fold (0.08 log units) above the measured number, within the range that was stated.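

Methoxy in place of methyl at this place, on an aromatic carbon meta to a large group, brings the series onto the measurable scale: in this assay compound 4 gives a number, 82400 nM, so the 3-methoxyphenyl compound yields a value where the earlier compounds with this core showed only that trifluoromethyl could do so. The change can be read only as an at least 1.2-fold lower number from compound 2 to compound 4 (0.08 log units; that floor lies within the scatter), which shows that a number exists for this exchange but not that the exchange moves activity beyond what repeated measurements would scatter. The step has only a floor and no true size, because its starting point is a limit and not a number: the limit of > 100000 nM in this assay, at which 2 of the 4 values shown sit.

From the compounds shown here alone, how far the exchange really moves the number in this assay stays open, and compound 1 cannot settle it, since it differs from compound 4 in more than one place. Also open, going by these compounds, is what an ethoxy group, a hydroxyl group, an amine or a carboxylic acid would do on this same aromatic carbon, and whether methoxy would behave alike on another carbon of the ring.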